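Trimming the side chain of compound 1

This account rests on a few compounds, and the source may have more. Where it says the series, first, only, none or still open, it means among the compounds named here.

Among the measured compounds shown here, in a physicochemical assay for solubility, read by nephelometry, measured as kinetic solubility, at pH 2.0 (on this read-out lower numbers stand for lower solubility and higher numbers for higher solubility), compound 1 `CC(=O)NCc1csc(NC(=O)c2cc(C(C)(C)C)nn2Cc2ccccc2)n1` gives 12.5 ug/mL, the only true number among the three compounds measured so far. Compound 2 `NCc1csc(NC(=O)c2cnnn2Cc2ccccc2)n1` gives > 100 ug/mL, which is a limit of the assay and not a number. Compound 3 `NCc1csc(NC(=O)c2ccc(Cl)cc2)n1` gives > 100 ug/mL, which is also a limit. For the measured compounds named here, compound 1 is therefore the one compound with a reading that can be compared directly, and it sits under the limit reached by the other two.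

The next compound to be measured is compound 4 `Cc1csc(NC(=O)c2cc(C(C)(C)C)nn2Cc2ccccc2)n1`, which keeps the core of compound 1 and differs in one place: hydrogen in place of acetamido on a saturated chain carbon bound to an aromatic carbon. Hydrogen stands in place of acetamido on a saturated chain carbon bound to an aromatic carbon, so acetamidomethyl becomes methyl.

Going by the values given here, no two measured compounds differ in only one place, so no measured step guides this change. The forecast starts from compound 1 at 12.5 ug/mL and, as a judgement, expects a modest move in this assay toward lower numbers, slightly beyond the usual scatter. The expected change is a 2.5-fold lower number from compound 1 to compound 4 (0.40 log units; beyond the scatter). For compound 4 the estimated value is 5 ug/mL, with an expected range from 1.5 ug/mL to 15 ug/mL.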

Compound 4, solubility: < 1.6 ug/mL
Compound 4: a limit, no number; the forecaster's own chance of this, stated with the estimate: 10%; at least 3.1-fold (0.49 log units) between middle value and limit.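

Among the compounds shown here, this is the first pair of compounds that differ in only one place, so it gives the first direct reading of a single change: in this assay, going from acetamidomethyl to methyl on the core of compound 1 gives an at least 7.8-fold lower number from compound 1 to compound 4 (0.89 log units; beyond the scatter). The acetamido on this saturated chain carbon bound to an aromatic carbon therefore matters for this read-out, since replacing it with hydrogen moves the reading beyond the usual scatter. The value of compound 4 is a limit and not a number, so the step has a minimum size but no exact one: the limit of < 1.6 ug/mL in this assay, at which 1 of the 4 values shown sits.

The compounds shown leave open whether this reading depends on the acetamido itself or whether another group at this place would serve as well, and a hydroxymethyl or a carboxylic acid on the core of compound 1 would speak to that. Compound 2 and compound 3 both sit at the opposite limit, but each differs from compound 1 in more than one place, so neither can be used to judge this change: the limit of > 100 ug/mL in this assay, at which 2 of the 4 values shown sit.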